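A few compounds are considered here, and "the series" means these few. Any claim that something is new, unique, unknown or untested is made for them only; others in the source may bear on it.

Compound 1, `CC(=O)OC/C(=C\c1ccc(Cl)cc1)C(=O)c1ccc(Cl)cc1`, gives 5400 nM in a functional assay on T47D cells (Homo sapiens) for inhibition, read by sulforhodamine B assay, with a stated time of 48 h; a lower number here means a stronger inhibitor of growth, a higher number a weaker inhibitor of growth.
Compound 2, `CC(=O)OC/C(=C\c1ccc(Cl)cc1Cl)C(=O)c1ccc(Cl)cc1`, gives 5200 nM in this assay.
Compound 3, `CC(=O)OC/C(=C/c1ccc(Cl)cc1)C(=O)c1ccc(Cl)cc1`, gives 12000 nM in this assay.

Compounds 1 and 3 share everything but the drawing of one element: the two compounds have the same atoms and bonds and differ only in configuration as drawn: 1 of 1 stereo elements differ; a double bond is drawn E in compound 1 and Z in compound 3. This drawn difference goes with a step of a 2.2-fold higher number from compound 1 to compound 3 (0.35 log units; beyond the scatter), and that step rests on (the fact that compounds 1 and 3 differ only in the configuration as drawn). Compound 3 thus stands at the highest of the three measured numbers.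

On the core of compound 1 the change chloro in place of hydrogen on an aromatic carbon gives a 1.0-fold lower number from compound 1 to compound 2 (0.02 log units; within the scatter), so compounds 1 and 2 cannot be told apart in this assay.

Compound 4, `CC(=O)OC/C(=C/c1ccc(Cl)cc1Cl)C(=O)c1ccc(Cl)cc1`, has not been measured. It arises from compound 3 by chloro in place of hydrogen on an aromatic carbon, the same change as that from compound 1 to compound 2, made at a place described in the same words. Since that earlier step was a 1.0-fold lower number from compound 1 to compound 2 (0.02 log units; within the scatter), the step from compound 3 to compound 4 is expected to be no change at the digits printed from compound 3 to compound 4 (within the scatter). Compound 4 is therefore estimated at 12000 nM in this assay, with an expected range from 6000 nM to 24000 nM.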

Compound 4, concentration for 50% growth inhibition: 20000 nM
Compound 4: the middle estimate sits 1.7-fold (0.22 log units) below what was measured, within the range that was stated.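

In this assay, for the compounds shown here, the change from 4-chlorophenyl to 2,4-dichlorophenyl gives a 1.7-fold higher number from compound 3 to compound 4 (0.22 log units; within the scatter), so on the core of compound 3, as on the core of compound 1, it produces no step that can be told from the scatter. The change therefore carries from one core to the other without a readable difference between the two steps: the same change on two cores in this assay, a 1.0-fold lower number (0.02 log units; within the scatter) from compound 1 to compound 2 and a 1.7-fold higher number (0.22 log units; within the scatter) from compound 3 to compound 4, 1.7-fold (0.24 log units) apart, within the scatter of two such steps

This rests on only two pairs in a single assay, so it does not show that the change would behave alike on any other core, and the drawn configuration of the double bond still separates the dichloro pair, with a 3.8-fold higher number from compound 2 to compound 4 (0.59 log units; beyond the scatter), a step that rests on that one difference: the fact that compounds 2 and 4 differ only in the configuration as drawn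

The compounds shown leave open whether a methoxy group or an amine entering at the same place would follow the chloro group on both cores. They also leave open whether either configuration would hold its place in the series with a free hydroxyl group in place of the acetoxy group.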